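Open-Chain Hydroxy Ester in Place of the Oxolane

The source may hold more compounds than are shown below. What is called first, only, known or untested is meant among the compounds shown, and "the series" means these compounds.

Of the compounds shown here, three built on one shared core have been measured in a functional assay on DU-145 cells (Homo sapiens) for cytotoxicity, read by MTT assay; on this read-out lower numbers stand for stronger inhibition and higher numbers for weaker inhibition. Compound 1 `CC(C)=CC[C@@H](OC[C@@H](C)O)C1=CC(=O)c2c(O)ccc(O)c2C1=O` gives 14300 nM. Compound 2 `COCCO[C@H](CC=C(C)C)C1=CC(=O)c2c(O)ccc(O)c2C1=O` gives 43200 nM, and compound 3 `CC(C)=CC[C@@H](OC(=O)C1CCCO1)C1=CC(=O)c2c(O)ccc(O)c2C1=O` gives 10500 nM. Compound 3 and compound 1 lie within the scatter of each other, as a 1.4-fold lower number from compound 1 to compound 3 (0.13 log units; within the scatter) shows, whereas compound 2 stands apart from both: a 3.0-fold higher number from compound 1 to compound 2 (0.48 log units; beyond the scatter) and a 4.1-fold lower number from compound 2 to compound 3 (0.61 log units; beyond the scatter).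

Compound 4 `CCC(O)(CC)CC(=O)O[C@H](CC=C(C)C)C1=CC(=O)c2c(O)ccc(O)c2C1=O` differs from compound 3 only at the carbonyl carbon: 2-ethyl-2-hydroxybutyl in place of oxolan-2-yl on a carbonyl carbon. Among the measured compounds shown here, none of the measured steps alters this part of the molecule; the steps leading from compound 1 and compound 2 to compound 3 exchange an ether-linked chain for the ester as a whole, so they give no direct guide. The nearest analogy is the exchange between the two ether chains, where the chain carrying a hydroxyl gave the lower number. Because a 3.0-fold higher number from compound 1 to compound 2 (0.48 log units; beyond the scatter) accompanied the loss of that hydroxyl, and the entering 2-ethyl-2-hydroxybutyl brings one hydrogen-bond donor, one expects in this assay a 1.2-fold lower number from compound 3 to compound 4 (0.07 log units; within the scatter), a step that is at most slightly downward and may well stay within the scatter. Compound 4 is therefore estimated at 9000 nM, with a range from 4000 nM to 22000 nM.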

Compound 4, half-maximal inhibitory concentration: 67000 nM
Estimate against measurement, compound 4: 7.4-fold (0.87 log units) below; measured number above the stated range.
By their numbers in this assay, from the lowest: compounds 3 and 1 (each within the scatter of the next); then compounds 2 and 4 (each within the scatter of the next).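

At this position the change is not neutral: in this assay, 2-ethyl-2-hydroxybutyl in place of oxolan-2-yl on the carbonyl carbon gives a 6.4-fold higher number from compound 3 to compound 4 (0.80 log units; beyond the scatter), so the entering hydroxyl does not go with a lower number here as it did between the two ether chains. The ester link alone does not hold the number down either, as the open-chain hydroxy ester shows a 4.7-fold higher number from compound 1 to compound 4 (0.67 log units; beyond the scatter) and, with the step to the methoxy ether inside the scatter, a 1.6-fold higher number from compound 2 to compound 4 (0.19 log units; within the scatter); among the compounds shown, a low number therefore does not follow either the hydroxyl or the ester, and compound 4 goes against both patterns. No measured evidence on this series accounts for the step.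

The compounds shown do not separate the loss of the oxolane ring from the gain of the hydroxyl or from the larger branched chain, and a 2-ethylbutyl group without the hydroxyl, or a cyclopentyl ring, on the same carbonyl carbon would pull these apart. Going by these compounds, whether a pyrrolidin-2-yl group, which carries an amine in the ring, would stay near compound 3 also remains open.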